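The source may report more compounds than this note shows. Statements on the series, on what has been measured and on what is new or still open speak of the compounds shown alone.

Notes on the series. Compound 1 `O=[N+]([O-])c1ccccc1S(=O)(=O)N1CC(n2cnc3c(Br)ncnc32)OCc2ccccc21` is recorded as "not determined" (no result reported) in a functional assay on MDA-MB-231 cells (Homo sapiens) for cytotoxicity, read by sulforhodamine B assay, with a stated time of 3 days; on this read-out higher numbers stand for weaker inhibition and lower numbers for stronger inhibition. Compound 2 `O=[N+]([O-])c1ccc(S(=O)(=O)N2CC(n3cnc4c(Cl)nc(Cl)nc43)OCc3ccccc32)cc1` gives 166 nM in this assay, and compound 3 `O=[N+]([O-])c1ccccc1S(=O)(=O)N1CC(n2cnc3c(Cl)nc(Cl)nc32)OCc2ccccc21` gives 280 nM. Going by the values given here, the only step with two numbers, a 1.7-fold higher number from compound 2 to compound 3 (0.23 log units; within the scatter), concerns the sulfonyl substituent and not a halogen. Compound 3 thus stands at the top of the two numbers, though within the scatter of compound 2, with compound 1 beside them without a number. Compound 4 `O=[N+]([O-])c1ccccc1S(=O)(=O)N1CC(n2cnc3c(I)nc(Cl)nc32)OCc2ccccc21` differs from compound 3 by iodo in place of chloro on an aromatic carbon. Among the compounds with values here, no measured step alters a halogen on this ring, so nothing here speaks for a shift beyond the scatter in this assay. The expected step is a 1.1-fold lower number from compound 3 to compound 4 (0.03 log units; within the scatter). Compound 4 is estimated at 260 nM, between 100 nM and 700 nM.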

Compound 4, half-maximal inhibitory concentration: 256 nM
Compound 4: the middle estimate sits 1.0-fold (0.01 log units) above what was measured, and the stated range covers the measured number.
By their numbers in this assay, from the lowest: compounds 2, 4 and 3 (each within the scatter of the next).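

Iodo in place of chloro, on the aromatic carbon next to the ring nitrogen, gives a 1.1-fold lower number from compound 3 to compound 4 (0.04 log units; within the scatter). Going by these compounds alone, this is the first measured step at a halogen on this ring, and in this pair the exchange of one halogen for another produces no shift beyond the scatter. Nothing available gives a reason for this result.

On these data alone, whether a non-halogen group at this carbon, such as an amine or a methoxy group, would keep the number in this assay at this level remains open. Also open, as far as these compounds go, is what the remaining chloro group on the ring contributes.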